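Ethoxycarbonyl in Place of Methyl: Expected Cytotoxicity

This account rests on a few compounds, and the source may have more. Where it says the series, first, only, none or still open, it means among the compounds named here.

Measured in an ADME assay on MT4 cells (Homo sapiens) for cytotoxicity; a higher number here means that more compound is tolerated, a lower number that less compound is tolerated:
Compound 1 `O=C(CSc1snnc1-c1ccc(Cl)cc1Cl)Nc1ccccc1Br` — >= 146000 nM, a limit of the assay.
Compound 2 `Cc1ccc(NC(=O)CSc2snnc2-c2ccc(Cl)cc2Cl)c(Br)c1` — > 255000 nM, a limit of the assay.
Compound 3 `O=C(CSc1snnc1-c1ccc(Cl)cc1Cl)Nc1ccccc1F` — 19500 nM.

Compound 2 stands only at the limit of > 255000 nM in this assay, at which 1 of the 3 values shown sits, so its number is not known. Compound 1 likewise sits at a limit, (the limit of >= 146000 nM in this assay, at which 1 of the 3 values shown sits). Compound 4 `CCOC(=O)c1ccc(NC(=O)CSc2snnc2-c2ccc(Cl)cc2Cl)c(Br)c1` differs from compound 2 by ethoxycarbonyl in place of methyl on an aromatic carbon. For the measured compounds named here, no measured step alters that position with a readable size: a step that the two limits leave unreadable from compound 1 to compound 2, while an at least 7.4-fold lower number from compound 1 to compound 3 (0.87 log units; beyond the scatter) and an at least 13-fold lower number from compound 2 to compound 3 (1.11 log units; beyond the scatter) concern the bromo group and the whole anilide instead. Compound 4 is therefore expected to remain near the upper region, with an at least 1.7-fold lower number from compound 2 to compound 4 (0.23 log units; that floor lies within the scatter) likely unreadable again. For compound 4 the estimate in this assay is 150000 nM, ranging from 40000 nM to 300000 nM.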

Compound 4, half-maximal cytotoxic concentration: > 228000 nM
Compound 4: only a limit was reported (the forecaster's own chance of this, stated with the estimate: 60%); at least 1.5-fold (0.18 log units) between middle value and limit.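

In this assay compound 4 gives > 228000 nM, which is a limit of the assay, and its steps from compound 1 and compound 2, themselves limits, cannot be read. On these data alone, whether ethoxycarbonyl in place of methyl shifts the number at all remains open.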